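The source may report more compounds than this note shows. Statements on the series, on what has been measured and on what is new or still open speak of the compounds shown alone.

Measured compounds:

Compound 1, `CC(C)(C)OC(=O)NCC#Cc1ccc2c(c1)C=C([N+](=O)[O-])C(C(F)(F)F)O2`, in an assay on isolated protein for inhibition of D(1B) dopamine receptor (Homo sapiens) (a lower number here means a stronger inhibitor, a higher number a weaker inhibitor), compound 1 gives 1250 nM.
Compound 2, `C[Si](C)(C)C#Cc1ccc2c(c1)C=C([N+](=O)[O-])C(C(F)(F)F)O2`, in this assay compound 2 gives 4200 nM.
Compound 3, `O=C1c2ccccc2C(=O)N1CC#Cc1ccc2c(c1)C=C([N+](=O)[O-])C(C(F)(F)F)O2`, in this assay compound 3 gives 1400 nM.

Compound 2 has the highest number of the three, so it is the weakest of these inhibitors in this assay; compound 3 and compound 1 both sit clearly lower. The unmeasured compound 4, `CC(=O)NCC#Cc1ccc2c(c1)C=C([N+](=O)[O-])C(C(F)(F)F)O2`, shares the core of compound 2 and differs from it in one place: a group of 5 heavy atoms (3 carbon, 1 nitrogen, 1 oxygen; no ring) in place of a group of 4 heavy atoms (3 carbon, 1 silicon; no ring), on a triple-bonded carbon.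

The step that bears on this is a 3.4-fold higher number from compound 1 to compound 2 (0.53 log units; beyond the scatter), in which a nitrogen-containing chain on the triple-bonded carbon was exchanged for the silicon group. Compound 4 restores a nitrogen-containing chain at that position, and the carbonyl and amide hydrogen it carries resemble the group of compound 1. Since compound 1 gives 1250 nM and compound 3 gives 1400 nM, both below compound 2, a step in the lowering direction, beyond the scatter, is expected.

For compound 4 the estimated value in this assay is 1300 nM, with a range from 500 nM to 3500 nM. This means an expected step of a 3.2-fold lower number from compound 2 to compound 4 (0.51 log units; beyond the scatter).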

Compound 4, inhibition constant: 1100 nM
Estimate against measurement, compound 4: 1.2-fold (0.07 log units) above; the range from low to high includes it.
By their numbers in this assay, from the lowest: compounds 4, 1 and 3 (each within the scatter of the next); then compound 2.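

Placing acetamidomethyl on the triple-bonded carbon in this assay gives a 3.8-fold lower number from compound 2 to compound 4 (0.58 log units; beyond the scatter) and shows that a second, much smaller nitrogen-containing chain also gives a lower number than the silicon group. The earlier compounds shown here could not show how much of the chain in compound 1 this result depends on. Methyl in place of tert-butoxy on the carbonyl carbon gives a 1.1-fold lower number from compound 1 to compound 4 (0.06 log units; within the scatter) and so leaves the number unchanged within the scatter, which means that the tert-butoxy group is not needed to keep this level of inhibition.

The compounds shown leave open how a simple amine, a carboxylic acid or a longer chain on the same triple-bonded carbon would compare with acetamidomethyl. No measurement shown explains the difference between these chains and the silicon group.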